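Pentylamino Gives Way to Fluorophenylamino on a Shared Core

This account rests on a few compounds, and the source may have more. Where it says the series, first, only, none or still open, it means among the compounds named here.

Compound 1 `CCCOc1ccc(C(=O)Nc2cnccn2)cc1` gives 22500 nM in an in vitro assay on HEK-tsA201 cells for antagonist activity at Neuronal acetylcholine receptor; alpha3/beta4 (Homo sapiens), read by fluorescence and calcium flux; on this read-out lower numbers stand for stronger inhibition and higher numbers for weaker inhibition. Compound 2 `CCCCCNc1cccc(NC(=O)c2ccc(OCCC)cc2)n1` is known in this assay by a limit rather than a number, > 100000 nM, namely (the limit of > 100000 nM in this assay, at which 1 of the 2 values shown sits). Compound 3 `CCCOc1ccc(C(=O)Nc2cccc(Nc3ccc(F)cc3)n2)cc1` differs from compound 2 in one place: 4-fluorophenyl in place of pentyl on a nitrogen on an aromatic ring. Going by the values given here, no step between two measured compounds is available to guide the size of this change, so the estimated step of an at least 1.6-fold lower number from compound 2 to compound 3 (0.22 log units; that floor lies within the scatter) is expected to stay within the usual scatter, with no clear direction. Compound 3 is therefore expected to give about 60000 nM in this assay, with a range from 15000 nM to 250000 nM.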

Compound 3, half-maximal inhibitory concentration: > 100000 nM
Compound 3 gave a limit, no number (the forecaster's own chance of this, stated with the estimate: 45%); middle value at least 1.6-fold (0.22 log units) from the limit.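

No step can be read between compound 2 and compound 3, because each gives a limit and not a number: the limit of > 100000 nM in this assay, at which 2 of the 3 values shown sit.

The compounds shown leave open how pentylamino and (4-fluorophenyl)amino truly compare in this assay.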